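The source may report more compounds than this note shows. Statements on the series, on what has been measured and on what is new or still open speak of the compounds shown alone.

Measured compounds:
compound 1, `CC(O)(CSc1ccc(C(F)(F)F)cc1)C(=O)Nc1cccc(S(F)(F)(F)(F)F)c1`, 27200 nM
compound 2, `CC(O)(CSc1cccc(C(F)(F)F)c1)C(=O)Nc1cccc(S(F)(F)(F)(F)F)c1`, 19100 nM
compound 3, `CC(O)(CS(=O)(=O)c1ccc(C(F)(F)F)cc1)C(=O)Nc1ccc(S(F)(F)(F)(F)F)cc1`, 29300 nM

All three values come from a functional assay on DU-145 cells (Homo sapiens) for antiproliferative activity, read by propidium iodide staining, with a stated time of 96 h; on this read-out lower numbers stand for stronger inhibition and higher numbers for weaker inhibition. Compound 1 and compound 2 differ by a single change, (3-(trifluoromethyl)phenyl in place of 4-(trifluoromethyl)phenyl on a sulfur), and the step is a 1.4-fold lower number from compound 1 to compound 2 (0.15 log units; within the scatter), so the two values do not separate from one another. Compound 3 has a different core from compound 1; how the two cores differ is not broken down here. Its value sits close to those of compound 1 and compound 2, and none of the three is set apart from the others.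

Compound 4, `CC(O)(CS(=O)(=O)c1cccc(C(F)(F)F)c1)C(=O)Nc1ccc(S(F)(F)(F)(F)F)cc1`, has not been measured in this assay. It is made from compound 3 by 3-(trifluoromethyl)phenyl in place of 4-(trifluoromethyl)phenyl on a sulfonyl sulfur. This is the same kind of change as that from compound 1 to compound 2, but not the same: there the place was on a sulfur whose other neighbours are saturated chain carbon, here it is on a sulfonyl sulfur whose other neighbours are saturated chain carbon. Because the earlier step was a 1.4-fold lower number from compound 1 to compound 2 (0.15 log units; within the scatter), compound 4 is expected to sit near compound 3, with an expected step of a 1.3-fold lower number from compound 3 to compound 4 (0.12 log units; within the scatter). The estimate for compound 4 is 22000 nM, expected to lie between 12000 nM and 42000 nM.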

Compound 4, half-maximal inhibitory concentration: 31900 nM
Compound 4: middle estimate off by 1.5-fold (0.16 log units), on the low side; low and high end bracket the measured number.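

In this assay the new step is a 1.1-fold higher number from compound 3 to compound 4 (0.04 log units; within the scatter), so the two values do not separate. Set beside the same change on the other core, this step cannot be told apart from the earlier one: the same change on two cores in this assay, a 1.4-fold lower number (0.15 log units; within the scatter) from compound 1 to compound 2 and a 1.1-fold higher number (0.04 log units; within the scatter) from compound 3 to compound 4, 1.6-fold (0.19 log units) apart, within the scatter of two such steps. The change thus leaves the value within the scatter on both cores, and nothing here suggests that its outcome depends on the core; but neither step lies beyond the scatter, so the pair shows no effect of a measurable size that could be said to carry over, and a small effect of opposite sign on the two cores cannot be ruled out.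

The compounds shown leave open whether replacing trifluoromethyl on this phenyl ring with a nitrile, an amine or a carboxylic acid would move the value clear of the scatter. They also leave open whether a longer chain between the sulfur and the hydroxyl-bearing carbon would do so.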